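Replacing diethylamino with cyclopentylamino on a urea carbonyl

A few compounds are considered here, and "the series" means these few. Any claim that something is new, unique, unknown or untested is made for them only; others in the source may bear on it.

The three measured compounds share one core and differ only in the group on the carbonyl carbon of the urea. Compound 1 `COc1cc(NC(C)CCCNC(=O)NCC2CCCCC2)c2ncccc2c1` carries (cyclohexylmethyl)amino there, compound 3 `COc1cc(NC(C)CCCNC(=O)NCc2ccccc2)c2ncccc2c1` carries benzylamino, and compound 2 `CCN(CC)C(=O)NCCCC(C)Nc1cc(OC)cc2cccnc12` carries diethylamino. In a functional assay on MCF7 cells (Homo sapiens), read by MTT assay, with a stated time of 72 h (a lower number here means a stronger inhibitor, a higher number a weaker inhibitor), compound 1 gives 61000 nM. Compound 3 gives 25000 nM in this assay. For compound 2 this assay gives only a limit, > 63000 nM, so compound 2 stands at the weak end of what was measured and its number is not known (the limit of > 63000 nM in this assay, at which 1 of the 3 values shown sits).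

Compound 4 `COc1cc(NC(C)CCCNC(=O)NC2CCCC2)c2ncccc2c1` is the unmeasured member. Its change from compound 2 is cyclopentylamino in place of diethylamino on a carbonyl carbon. Within the data shown here, two measured steps bear on it. The step of an at least 2.5-fold lower number from compound 2 to compound 3 (0.40 log units; beyond the scatter) shows that putting a ring-bearing amine back in place of diethylamino gave a stronger compound, and the step of an at least 1.0-fold higher number from compound 1 to compound 2 (0.01 log units; that floor lies within the scatter) shows that removing such a ring cost nothing that the assay could resolve. A cyclopentyl ring attached directly to the amine nitrogen resembles the ring of compound 1 more than the aromatic ring of compound 3, so a modest step downward is expected, an at least 1.5-fold lower number from compound 2 to compound 4 (0.19 log units; that floor lies within the scatter). Compound 4 is therefore expected to give about 40000 nM in this assay, within the range 15000 nM to 100000 nM.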

Compound 4, half-maximal inhibitory concentration: 30000 nM
For compound 4 the middle estimate is 1.3-fold (0.12 log units) above the measured one; the measured number falls inside the stated range.
By their numbers in this assay, from the lowest: compounds 3 and 4 (each within the scatter of the next); then compound 1. At a limit, above all of these: compound 2.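

In this assay, a saturated ring set directly on the urea nitrogen gives a step that clears the scatter, an at least 2.1-fold lower number from compound 2 to compound 4 (0.32 log units; beyond the scatter), whereas the earlier comparison of compound 1 with compound 2 resolved nothing. The ring need not be the benzyl of compound 3, since the cyclopentyl of compound 4 cannot be told apart from it, a 1.2-fold higher number from compound 3 to compound 4 (0.08 log units; within the scatter), while the saturated groups themselves do not behave alike, as cyclopentyl in place of cyclohexylmethyl gives a 2.0-fold lower number from compound 1 to compound 4 (0.31 log units; beyond the scatter). The full size of the step from the diethylamino compound remains unknown, as compound 2 is held only by a limit: the limit of > 63000 nM in this assay, at which 1 of the 4 values shown sits.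

The last comparison changes ring size and the link to the nitrogen together, so cyclohexylamino or cyclopentylmethylamino on the same carbonyl carbon would be needed to tell those two changes apart. The change from compound 2 to compound 4 also adds a hydrogen-bond donor along with the ring, and a pyrrolidine joined through its nitrogen, which has a ring but no hydrogen on that nitrogen, would show which of the two goes with the stronger number.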